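A few compounds are considered here, and "the series" means these few. Any claim that something is new, unique, unknown or untested is made for them only; others in the source may bear on it.

Working notes on the series. The shared core is carried by compound 1 `CC(c1cc(F)c(F)c(F)c1)N1CC2(CCN(c3nc(=O)c4cc(C(F)(F)F)cc([N+](=O)[O-])c4s3)CC2)C1`, compound 2 `CC(c1ccc(OC(F)(F)F)cc1)N1CC2(CCN(c3nc(=O)c4cc(C(F)(F)F)cc([N+](=O)[O-])c4s3)CC2)C1` and compound 3 `O=c1nc(N2CCN(CC3CCCCC3)CC2)sc2c([N+](=O)[O-])cc(C(F)(F)F)cc12`. In an ADME assay on the whole organism (Mus musculus, strain BALB/c) for pharmacokinetics, read by HPLC, with a stated time of 24 h, at a dose of 12.5 mg/kg by the oral route (a lower number here means less compound in the circulation, a higher number more compound in the circulation at the dose given), compound 1 gives 430 nM, compound 2 gives 1550 nM and compound 3 gives 1610 nM. Of the three numbers compound 2 is second highest, but its gap to compound 3 lies within the scatter, whereas the step of a 3.6-fold higher number from compound 1 to compound 2 (0.56 log units; beyond the scatter) is beyond the scatter.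

Compound 4 `CC(c1ccc(C(F)(F)F)cc1)N1CC2(CCN(c3nc(=O)c4cc(C(F)(F)F)cc([N+](=O)[O-])c4s3)CC2)C1` has not yet been measured. It differs from compound 2 in one place: trifluoromethyl in place of trifluoromethoxy on an aromatic carbon. For the measured compounds named here, only one measured step touches this part of the molecule, a 3.6-fold higher number from compound 1 to compound 2 (0.56 log units; beyond the scatter), and there the whole aryl ring was exchanged, not the one group alone. Going by the values given here, no measured pair sets trifluoromethyl against trifluoromethoxy on the same ring, so the steps in hand give no direction for the present change and no size for it. The step from compound 2 to compound 4 is therefore expected to stay within the scatter, no change at the digits printed from compound 2 to compound 4 (within the scatter). Compound 4 is expected to give 1550 nM, with a range from 700 nM to 3400 nM.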

Compound 4, maximal plasma concentration: 2160 nM
For compound 4 the middle estimate is 1.4-fold (0.14 log units) below the measured one; the range from low to high includes it.
By their numbers in this assay, from the lowest: compound 1; then compounds 2, 3 and 4 (each within the scatter of the next).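

For the compounds shown here, the exchange of trifluoromethoxy for trifluoromethyl on this aromatic carbon is the first change of the single group alone in this assay (a 1.4-fold higher number from compound 2 to compound 4 (0.14 log units; within the scatter)), so the position tolerates the loss of the oxygen with no change beyond the scatter. Compound 4 also extends the reading from the exchange of the whole ring: with 4-(trifluoromethyl)phenyl in place of 3,4,5-trifluorophenyl (a 5.0-fold higher number from compound 1 to compound 4 (0.70 log units; beyond the scatter)), a second ring carrying one fluorinated group at this position stands clear of compound 1, as compound 2 does (a 3.6-fold higher number from compound 1 to compound 2 (0.56 log units; beyond the scatter)). No measurement in hand bears on the origin of these differences.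

The compounds shown do not separate the effect of the group at this position from that of the two further fluorines of compound 1, since both exchanges alter the ring as a whole. Going by these compounds, whether the level seen for compound 2 and compound 4 holds with a nitrile, an amine, a carboxylic acid or a plain hydrogen on this aromatic carbon remains open.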